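This account rests on a few compounds, and the source may have more. Where it says the series, first, only, none or still open, it means among the compounds named here.

Measured compounds:
Compound 1, `CO[C@@]12CCN(Cc3ccccc3)C[C@H]1[C@H](c1ccc3ccccc3c1)C(C#N)=C(N)O2`: 23400 nM
Compound 2, `CCCN1CC[C@@]2(OC)OC(N)=C(C#N)[C@@H](c3ccc(F)cc3)[C@@H]2C1`: 29600 nM

Both compounds were tested in a functional assay on trachea (Cavia porcellus); a higher number here means a weaker inhibitor, a lower number a stronger inhibitor. Compound 1 gives 23400 nM there, and compound 2 gives 29600 nM; the two numbers lie within the usual scatter of each other, so neither can be called the weaker or the stronger inhibitor on this evidence. Compound 2 is the starting point for the next step.

Compound 3, `CO[C@@]12CCN(Cc3ccccc3)C[C@H]1[C@H](c1ccc(F)cc1)C(C#N)=C(N)O2`, has not yet been measured in this assay. It differs from compound 2 in one place: phenyl in place of ethyl on a saturated chain carbon bound to an amine nitrogen in a ring. Compound 1 already carries a benzyl group on that ring nitrogen and its number sits close to that of compound 2, so there is no sign in these two results that the group on this nitrogen moves the value by much.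

Among the measured compounds shown here, with no measured step of this kind to lean on, the expectation for compound 3 is a value close to that of compound 2, with a step of a 1.2-fold lower number from compound 2 to compound 3 (0.07 log units; within the scatter) that stays within the scatter. Compound 3 is therefore estimated at 25000 nM, with a likely range from 8000 nM to 80000 nM.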

Compound 3, half-maximal inhibitory concentration: 17200 nM
Estimate against measurement, compound 3: 1.5-fold (0.16 log units) above; low and high end bracket the measured number.
By their numbers in this assay, from the lowest: compounds 3, 1 and 2 (each within the scatter of the next).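

In this assay, replacing the propyl on the amine nitrogen in a ring with benzyl gives a 1.7-fold lower number from compound 2 to compound 3 (0.24 log units; within the scatter) and stays within the usual scatter, so this first direct comparison at this position finds no measurable difference between the two groups. The second change, 4-fluorophenyl in place of naphthalen-2-yl on a saturated ring carbon, gives a 1.4-fold lower number from compound 1 to compound 3 (0.13 log units; within the scatter) and also stays within the scatter, so neither single change separates these compounds in this test. No further measurement is available that could explain these small steps.

The compounds shown carry only propyl or benzyl on that nitrogen, so it remains open whether a longer chain such as phenylethyl, or a chain ending in a carboxylic acid, would move the number beyond the scatter. On these data alone, the methoxy group, the nitrile and the amino group are the same in all three compounds, so the part each one plays in the measured values also remains unknown.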